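This account rests on a few compounds, and the source may have more. Where it says the series, first, only, none or still open, it means among the compounds named here.

Measured in a functional assay on RAW264.7 cells (Mus musculus) for inhibition, read by Griess assay, with stated times of 2 h and 24 h; a lower number here means a stronger inhibitor, a higher number a weaker inhibitor: compound 1 `CCn1cc(COc2cc(O)c3c(c2)O[C@H](c2ccc(OC)c(O)c2)C/C3=N\O)nn1` gives 3140 nM; compound 2 `COc1ccc([C@@H]2C/C(=N\O)c3c(O)cc(OCc4cn(Cc5ccccc5C)nn4)cc3O2)cc1O` gives 18000 nM; compound 3 `COc1ccc([C@@H]2CC(=O)c3c(O)cc(OCc4cn(Cc5ccccc5F)nn4)cc3O2)cc1O` gives 7320 nM.

Compound 3 thus stands second highest of the three, with compound 1 lower and compound 2 higher, both gaps beyond the scatter. Compound 4 `COc1ccc([C@@H]2CC(=O)c3c(O)cc(OCc4cn(Cc5ccc(F)cc5)nn4)cc3O2)cc1O` differs from compound 3 only in this way: 4-fluorophenyl in place of 2-fluorophenyl on a saturated chain carbon bound to an aromatic nitrogen. Among the measured compounds shown here, the one measured step, a 5.7-fold higher number from compound 1 to compound 2 (0.76 log units; beyond the scatter), changes what sits at the same place but swaps a small group for a larger one, so it does not directly show what moving the fluorine does. For the measured compounds named here, with no step of this kind measured, the change is expected to fall within the scatter, giving a 1.0-fold lower number from compound 3 to compound 4 (0.02 log units; within the scatter). Compound 4 is therefore estimated at 7000 nM, with a range of 3000 nM to 16000 nM.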

Compound 4, half-maximal inhibitory concentration: 15100 nM
For compound 4 the middle estimate is 2.2-fold (0.33 log units) below the measured one; low and high end bracket the measured number.
By their numbers in this assay, from the lowest: compound 1; then compound 3; then compounds 4 and 2 (each within the scatter of the next).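

In this assay moving the fluorine alone, with the heavy-atom count unchanged, gives a 2.1-fold higher number from compound 3 to compound 4 (0.31 log units; beyond the scatter) so 4-fluorophenyl gives a weaker inhibitor than 2-fluorophenyl here. This position therefore responds to where the fluorine sits on the ring, which the earlier swap of methyl for 2-methylphenyl could not show. Nothing available explains the difference.

From the compounds shown here alone, it remains open how a plain phenyl or a 4-chlorophenyl group would compare at this place. Also open, going by these compounds, is whether moving the fluorine has the same effect on the core of compound 1.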